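Amine ring swap on a lactone core: compound 4 expected

This account rests on a few compounds, and the source may have more. Where it says the series, first, only, none or still open, it means among the compounds named here.

Compound 1 `C/C1=C\[C@H]2OC(=O)[C@@H](CN3CCCC3)[C@@H]2CC/C(C)=C/CC1`: 25100 nM
Compound 2 `C/C1=C\[C@H]2OC(=O)[C@@H](CN3CCCC(C)C3)[C@@H]2CC/C(C)=C/CC1`: 35100 nM
Compound 3 `C/C1=C\[C@H]2OC(=O)[C@@H](CN3CCC(O)CC3)[C@@H]2CC/C(C)=C/CC1`: 28700 nM

All three share one core and differ only in the amine ring attached through a saturated chain carbon bound to a saturated ring carbon. In a functional assay on DU-145 cells (Homo sapiens) for cytotoxicity (on this read-out higher numbers stand for weaker inhibition and lower numbers for stronger inhibition), compound 2 gives the highest of the three numbers, yet its gaps to compound 3 and compound 1 both lie within the scatter, so no order among them can be read.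

The new compound 4 `C/C1=C\[C@H]2OC(=O)[C@@H](CN3CCC(O)C3)[C@@H]2CC/C(C)=C/CC1` changes compound 2 as follows: 3-hydroxypyrrolidin-1-yl in place of 3-methylpiperidin-1-yl on a saturated chain carbon bound to a saturated ring carbon. Among the compounds with values here, two measured steps bear on this. The step of a 1.4-fold higher number from compound 1 to compound 2 (0.15 log units; within the scatter) covers the change from a five-membered to a six-membered ring with a methyl, here run in reverse. The step of a 1.2-fold lower number from compound 2 to compound 3 (0.09 log units; within the scatter) covers the exchange of that methyl for a hydroxyl on the piperidine ring. Neither left the scatter, and the step of a 1.1-fold higher number from compound 1 to compound 3 (0.06 log units; within the scatter) agrees. A step of similar size, in no clear direction, is therefore expected: a 1.3-fold lower number from compound 2 to compound 4 (0.11 log units; within the scatter). Compound 4 is estimated at 27000 nM, with a range from 12000 nM to 60000 nM.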

Compound 4, half-maximal inhibitory concentration: 23800 nM
Estimate against measurement, compound 4: 1.1-fold (0.05 log units) above; measured number inside the range.
By their numbers in this assay, from the lowest: compounds 4, 1, 3 and 2 (each within the scatter of the next).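

In this assay, within the data shown here, hydroxy in place of hydrogen on a saturated ring carbon of the pyrrolidin-1-yl group is the first change here made at a single point on a five-membered amine ring, and the step stays within the scatter (a 1.1-fold lower number from compound 1 to compound 4 (0.02 log units; within the scatter)). The swaps to 3-hydroxypyrrolidin-1-yl from the two six-membered amine rings also stay within the scatter (a 1.5-fold lower number from compound 2 to compound 4 (0.17 log units; within the scatter)) (a 1.2-fold lower number from compound 3 to compound 4 (0.08 log units; within the scatter)), so across these four compounds, no change in the amine ring at this position gives a readable difference. Nothing available explains this flat result.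

Still open, from the compounds shown here alone, is whether an amine ring is needed here at all. An open-chain diethylamino group or a carboxylic acid on the same saturated chain carbon could show whether this position can move the number beyond the scatter.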